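Swapping phenyl for furan-2-yl at the amide carbonyl

The compounds below may be only part of what the source reports. "The series", "measured", "known", "first", "only" and "open" are said of these compounds alone.

Three amides built on the same core have been measured in an assay on HEK293 cells for binding affinity to Urotensin-2 receptor (Homo sapiens), read by radioligand binding; on this read-out higher numbers stand for weaker inhibition and lower numbers for stronger inhibition. Compound 1 `Cc1cc(C(=O)N[C@H]2CCN(Cc3ccc(OCCCN(C)C)cc3)C2)ccc1Cl` gives 631 nM. Compound 3 `CN(C)CCCOc1ccc(CN2CC[C@H](NC(=O)c3ccccc3)C2)cc1` gives 2510 nM. For compound 2 `CN(C)CCCOc1ccc(CN2CC[C@H](NC(=O)c3ccc(C#N)cc3)C2)cc1` only a limit is reported, < 10000 nM, so its number is not known. Among the two readable numbers compound 3 stands highest; its nearest neighbour is compound 1, and a 4.0-fold higher number from compound 1 to compound 3 (0.60 log units; beyond the scatter) separates them. The steps a step that the limit leaves unreadable from compound 1 to compound 2 and a step that the limit leaves unreadable from compound 2 to compound 3 cannot be sized because of the limit of < 10000 nM in this assay, at which 1 of the 3 values shown sits.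

Compound 4 `CN(C)CCCOc1ccc(CN2CC[C@H](NC(=O)c3ccco3)C2)cc1` differs from compound 3 by furan-2-yl in place of phenyl on a carbonyl carbon. Among the measured compounds shown here, no measured step exchanges the phenyl for a five-membered aromatic ring, so the only guide is the behaviour of this position: removing chloro and methyl from compound 1 raised the number in this assay by a 4.0-fold higher number from compound 1 to compound 3 (0.60 log units; beyond the scatter), whereas replacing them by cyano gave compound 2 only a limit. The exchange to furan-2-yl is therefore expected to move the number little, if at all, and more likely upward than downward. Compound 4 is expected to give 3500 nM, with a plausible range from 1200 nM to 10000 nM. This estimate implies an expected step of a 1.4-fold higher number from compound 3 to compound 4 (0.14 log units; within the scatter).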

Compound 4, inhibition constant: < 10000 nM
Compound 4 gave a limit, no number; the forecaster's own chance of this, stated with the estimate: 30%; the middle value lies beyond the limit too.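

In this assay compound 4 gives < 10000 nM, which is a limit and not a number. The steps joining compound 4 to compound 1, compound 2 and compound 3 therefore cannot be read, because they all end at this limit: the limit of < 10000 nM in this assay, at which 2 of the 4 values shown sit.

The compounds shown leave open whether furan-2-yl in place of phenyl changes the number at all, and in which direction.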